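A few compounds are considered here, and "the series" means these few. Any claim that something is new, unique, unknown or untested is made for them only; others in the source may bear on it.

Measured so far:
compound 1 `Cc1nc2c3ccccc3ccc2c2nc3c(ccc4ccccc43)c(-c3ccccc3N)c12` — 125 ug/mL
compound 2 `Cc1nc2c3ccccc3ccc2c2nc3c(ccc4ccccc43)c(C)c12` — 195 ug/mL

For the measured compounds named here, in a functional assay, with a stated time of 90 s (a lower number here means a stronger inhibitor, a higher number a weaker inhibitor), compound 1 gives the lowest of the two numbers so far; its nearest neighbour is compound 2, and the step of a 1.6-fold higher number from compound 1 to compound 2 (0.19 log units; within the scatter) stays within the scatter, so the two cannot be ordered on these data.

Compound 3 `Cc1nc2c3ccccc3ccc2c2nc3c(ccc4ccccc43)c(-c3ccccc3)c12` has not yet been measured in this assay. Against compound 1 it shows (hydrogen in place of amino on an aromatic carbon); the amino is lost while the phenyl stays in place.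

Going by the values given here, only one measured step bears on this change: a 1.6-fold higher number from compound 1 to compound 2 (0.19 log units; within the scatter), where the whole 2-aminophenyl was exchanged for methyl and the number did not move beyond the scatter. Taking away the amino alone is a smaller change than that, so no step beyond the scatter is expected here, with at most a slight drift upward.

For compound 3 the estimated value in this assay is 150 ug/mL, with a range from 75 ug/mL to 300 ug/mL. The expected step is therefore a 1.2-fold higher number from compound 1 to compound 3 (0.08 log units; within the scatter).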

Compound 3, half-maximal inhibitory concentration: 188 ug/mL
Estimate against measurement, compound 3: 1.3-fold (0.10 log units) below; measured number inside the range.
By their numbers in this assay, from the lowest: compounds 1, 3 and 2 (each within the scatter of the next).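

In this assay, taking away the amino while the phenyl stays in place leaves the number within the scatter (a 1.5-fold higher number from compound 1 to compound 3 (0.18 log units; within the scatter)). The phenyl itself also makes no readable difference against methyl at this aromatic carbon (a 1.0-fold lower number from compound 2 to compound 3 (0.02 log units; within the scatter)). The earlier exchange of 2-aminophenyl for methyl could not separate these two parts, and now neither part, taken alone, moves the number beyond the scatter. No measurement at hand explains this flat response.

Still open, going by these compounds, is whether any group at this carbon moves the number beyond the scatter, for example a carboxylic acid, a longer alkyl chain or a dimethylamino group on the phenyl. The compounds shown also say nothing about changes elsewhere on the shared core.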